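From Benzyloxy to Benzylamino on a Shared Core

The source may hold more compounds than are shown below. What is called first, only, known or untested is meant among the compounds shown, and "the series" means these compounds.

In an ADME assay on CCRF-CEM cells (Homo sapiens) for cytotoxicity, with a stated time of 4 days (on this read-out lower numbers stand for higher toxicity in this test and higher numbers for lower toxicity in this test), compound 1 `COC(=O)CCCC(=O)n1c(=O)c(C)cn([C@@H]2O[C@H](CO[Si](C)(C)C(C)(C)C)[C@@]3(OS(=O)(=O)C=C3N)[C@H]2O[Si](C)(C)C(C)(C)C)c1=O` gives 9900 nM and compound 2 `Cc1cn([C@@H]2O[C@H](CO[Si](C)(C)C(C)(C)C)[C@@]3(OS(=O)(=O)C=C3N)[C@H]2O[Si](C)(C)C(C)(C)C)c(=O)n(C(=O)CCCC(=O)OCc2ccccc2)c1=O` gives 9200 nM on the shared core. Going by the values given here, compound 2 therefore stands within the scatter of compound 1, its only neighbour on these numbers, and the two cannot be ranked.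

Compound 3 `Cc1cn([C@@H]2O[C@H](CO[Si](C)(C)C(C)(C)C)[C@@]3(OS(=O)(=O)C=C3N)[C@H]2O[Si](C)(C)C(C)(C)C)c(=O)n(C(=O)CCCC(=O)NCc2ccccc2)c1=O` is reached from compound 2 by one change benzylamino in place of benzyloxy on a carbonyl carbon with benzylamino in place of benzyloxy on a carbonyl carbon. Among the compounds with values here, no measured step makes this exchange. Within the data shown here, the nearest evidence is the single step measured so far, a 1.1-fold lower number from compound 1 to compound 2 (0.03 log units; within the scatter), which ends in the benzyloxy group that now leaves. That step bears on the change only loosely, and it shows that a change at this carbonyl end of the chain has so far left the number within the scatter.

Among the measured compounds shown here, with that step from compound 1 to compound 2 as the only guide, no step beyond the scatter is expected in this assay. The estimate for compound 3 means a 1.0-fold higher number from compound 2 to compound 3 (0.01 log units; within the scatter) as the expected step. Compound 3 is estimated at 9500 nM (expected range from 4500 nM to 20000 nM).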

Compound 3, half-maximal cytotoxic concentration: 8800 nM
For compound 3 the middle estimate is 1.1-fold (0.03 log units) above the measured one; measured number inside the range.
By their numbers in this assay, from the lowest: compounds 3, 2 and 1 (each within the scatter of the next).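

In this assay, benzylamino in place of benzyloxy on a carbonyl carbon whose other neighbour is a saturated chain carbon gives a 1.0-fold lower number from compound 2 to compound 3 (0.02 log units; within the scatter) and thus no readable shift, even though the two groups differ in their counts of hydrogen-bond donors and acceptors. The exchange of methoxy for benzylamino at the same carbonyl carbon gives a 1.1-fold lower number from compound 1 to compound 3 (0.05 log units; within the scatter) and so also stays within the scatter. Across compounds 1, 2 and 3, then, this position has tolerated methoxy, benzyloxy and benzylamino with no step that can be read, and none of the three compounds goes against that, though nothing shown here explains why the numbers stay so close.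

The compounds leave open whether a carboxylic acid, a primary amine or a longer chain at this carbonyl carbon would carry the number beyond the scatter. They also leave open whether benzylamino and benzyloxy would stay this close on a core other than the shared one.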